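Benzoxazole to benzothiazole at the thioether of compound 3

The source may hold more compounds than are shown below. What is called first, only, known or untested is meant among the compounds shown, and "the series" means these compounds.

Compound 3 `Cc1ccc2oc(SCC(=O)Nc3ccc(-c4nc(-c5ccccc5)c(-c5ccccc5)n4C)cc3)nc2c1` gives 1.1% in a functional assay on MCF7 cells (Homo sapiens) for cytotoxicity, read by MTT assay, with a stated time of 24 h, tested at 0.64 ug/mL (a higher number here means a stronger effect of the compound at the concentration tested, a lower number a weaker effect), the lowest of the three numbers measured: compound 2 `Cn1c(-c2ccc(NC(=O)CSc3nc4cc(Cl)ccc4o3)cc2)nc(-c2ccccc2)c1-c1ccccc1` gives 2.4%, within the scatter of it, while compound 1 `Cn1c(-c2ccc(NC(=O)CSc3nc4ccccc4o3)cc2)nc(-c2ccccc2)c1-c1ccccc1` gives 18.7%, the gap being a number 17.6 percentage points lower from compound 1 to compound 3 (beyond the scatter). Compound 4 `Cn1c(-c2ccc(NC(=O)CSc3nc4ccccc4s3)cc2)nc(-c2ccccc2)c1-c1ccccc1` differs from compound 3 by 1,3-benzothiazol-2-yl in place of 5-methyl-1,3-benzoxazol-2-yl on a sulfur. For the measured compounds named here, two measured steps bear on this: the methyl that enters in a number 17.6 percentage points lower from compound 1 to compound 3 (beyond the scatter) leaves again here, and a number 1.3 percentage points lower from compound 2 to compound 3 (within the scatter) shows the methyl and chloro variants of the benzoxazole as equivalent; no measured pair covers the oxygen-for-sulfur exchange in the ring. Compound 1 carries the unsubstituted ring and is the nearest reference, so a rise toward it is expected, tempered by the untested ring change: the estimated step is a number 10.9 percentage points higher from compound 3 to compound 4 (beyond the scatter), giving compound 4 an expected 12% with a range of 1% to 26%.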

Compound 4, a percentage reported as activity, at one concentration (the size of the read-out at that concentration, not a potency): 0.9%
Beside the measured number, compound 4's estimate is 11.1 percentage points above it; measured number below the stated range.
By their numbers in this assay, from the lowest: compounds 4, 3 and 2 (each within the scatter of the next); then compound 1.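

In this assay, the exchange of ring oxygen for ring sulfur now has a measured size: a number 17.8 percentage points lower from compound 1 to compound 4 (beyond the scatter). The 1,3-benzothiazol-2-yl group on the sulfur sits level with the substituted benzoxazoles: a number 0.2 percentage points lower from compound 3 to compound 4 (within the scatter) and a number 1.5 percentage points lower from compound 2 to compound 4 (within the scatter). Among these four compounds, only compound 1, with the unsubstituted 1,3-benzoxazol-2-yl group, stands apart.

Nothing available gives a reason for this pattern. Still open, on these data alone, is how a methoxy group or an amine on the benzothiazole would read, and whether a longer chain at the sulfur would change the picture.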